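Working notes: ring-nitrogen substituent swap in the series

The source may hold more compounds than are shown below. What is called first, only, known or untested is meant among the compounds shown, and "the series" means these compounds.

Measured in a functional assay on MKN-74 cells (Homo sapiens) for antiproliferative activity, with a stated time of 24 h; a higher number here means a weaker inhibitor, a lower number a stronger inhibitor:
compound 1 `Cc1ccccc1CN1CCc2c(sc(NC(=O)c3ccccc3Cl)c2C(N)=O)C1` — > 50000 nM
compound 2 `NC(=O)c1c(NC(=O)c2ccc(C(F)(F)F)cc2)sc2c1CCN(Cc1c(Cl)cccc1Cl)C2` — 8530 nM
compound 3 `NC(=O)c1c(NC(=O)c2ccc(C(F)(F)F)cc2)sc2c1CCN(Cc1ccc(Cl)cc1Cl)C2` — 10900 nM

Compound 1 stands at the limit of > 50000 nM in this assay, at which 1 of the 3 values shown sits, so its value is a limit and not a number. Compounds 2 and 3 are numbered values within the scatter of each other: a 1.3-fold higher number from compound 2 to compound 3 (0.11 log units; within the scatter). Compound 4 `NC(=O)c1c(NC(=O)c2ccccc2Cl)sc2c1CCN(C(=S)Nc1ccccc1)C2` differs from compound 1 at the ring nitrogen: a group of 9 heavy atoms (7 carbon, 1 nitrogen, 1 sulfur; one six-membered aromatic ring of carbon only) in place of a group of 8 heavy atoms (8 carbon; one six-membered aromatic ring of carbon only), on an amine nitrogen in a ring. For the measured compounds named here, the only measured step concerns the dichlorophenyl groups of compounds 2 and 3 and does not touch the ring nitrogen, so no measured step bears on this change, and no direction can be drawn from it. Since compound 1 sits at a limit, compound 4 is expected near 30000 nM, range 8000 nM to 100000 nM, the expected step being an at least 1.6-fold lower number from compound 1 to compound 4 (0.22 log units; that floor lies within the scatter).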

Compound 4, half-maximal inhibitory concentration: 15600 nM
For compound 4 the middle estimate is 1.9-fold (0.28 log units) above the measured one; the range from low to high includes it.
By their numbers in this assay, from the lowest: compounds 2, 3 and 4 (each within the scatter of the next). At a limit, above all of these: compound 1.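

On an amine nitrogen in a ring, the shared core tolerates a change that gives a readable value: in this assay, the group of compound 4 in place of 2-methylbenzyl gives an at least 3.2-fold lower number from compound 1 to compound 4 (0.50 log units; beyond the scatter). This step is only a floor, as compound 1 is held at a limit and not a number: the limit of > 50000 nM in this assay, at which 1 of the 4 values shown sits.

The entering group adds sulfur, nitrogen, 1 hydrogen-bond donor and 1 hydrogen-bond acceptor together, so this one step cannot assign the difference to any of them. On these data alone, a urea with oxygen in place of sulfur, or an acetyl group on the same nitrogen, remains open.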